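This account rests on a few compounds, and the source may have more. Where it says the series, first, only, none or still open, it means among the compounds named here.

Compound 1 `CCC/C=C/C(=O)N(Cc1ccc(OC)c(O)c1)c1cc(OC)c(OC)c(OC)c1`: 57 nM
Compound 2 `COc1ccc(CN(C(=O)CO)c2cc(OC)c(OC)c(OC)c2)cc1O`: 370 nM

In a functional assay on KYSE-450 cells (Homo sapiens) for inhibition, read by MTT assay, with a stated time of 48 h (on this read-out higher numbers stand for weaker inhibition and lower numbers for stronger inhibition), compound 2 has the higher of the two numbers, at 370 nM. Compound 3 `COc1ccc(CN(C(=O)CN=[N+]=[N-])c2cc(OC)c(OC)c(OC)c2)cc1O` differs from it by one change: azido in place of hydroxy on a saturated chain carbon bound to a carbonyl carbon. Among the compounds with values here, only one measured step alters this part of the molecule, the modest 6.5-fold higher number from compound 1 to compound 2 (0.81 log units; beyond the scatter). That step replaced pent-1-en-1-yl with hydroxymethyl. Compound 3 keeps the chain carbon but loses the hydroxy, and a smaller move toward a lower number is expected in this assay, though a single step is thin evidence. The expected change is a 1.9-fold lower number from compound 2 to compound 3 (0.27 log units; within the scatter). For compound 3 the estimated value is 200 nM, with an expected range of 70 nM to 550 nM.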

Compound 3, half-maximal inhibitory concentration: 160 nM
Compound 3: middle estimate off by 1.3-fold (0.10 log units), on the high side; the measured number falls inside the stated range.
By their numbers in this assay, from the lowest: compound 1; then compound 3; then compound 2.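

In this assay the group on the saturated chain carbon bound to a carbonyl carbon matters by itself: azido in place of hydroxy gives a 2.3-fold lower number from compound 2 to compound 3 (0.36 log units; beyond the scatter) with the rest of the molecule unchanged. Azidomethyl recovers only part of the gap to pent-1-en-1-yl on the carbonyl carbon, with a 2.8-fold higher number from compound 1 to compound 3 (0.45 log units; beyond the scatter) still remaining. No measurement shown here accounts for either difference.

From the compounds shown here alone, whether an amine or a carboxylic acid on this chain carbon would do better than azido stays open. So does how a saturated pentyl chain on the carbonyl carbon would compare with pent-1-en-1-yl.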